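This account rests on a few compounds, and the source may have more. Where it says the series, first, only, none or still open, it means among the compounds named here.

Measured compounds:
compound 1, `CCN(Cc1ccccc1)C(=O)c1nn(-c2ccc(F)cc2)c(OC[C@@H](O)C[C@@H](O)CC(=O)O)c1C(C)C`, 14 nM
compound 2, `CC(C)c1c(C(=O)NCc2cccc(F)c2F)nn(-c2ccc(F)cc2)c1OC[C@@H](O)C[C@@H](O)CC(=O)O`, 2 nM
compound 3, `CC(C)c1c(C(=O)N2CCCCC2)nn(-c2ccc(F)cc2)c1OC[C@@H](O)C[C@@H](O)CC(=O)O`, 47 nM

All three share one core and differ only in the group on the carbonyl carbon. In an assay on microsomes from liver for inhibition of 3-hydroxy-3-methylglutaryl-coenzyme A reductase (Rattus norvegicus) (on this read-out higher numbers stand for weaker inhibition and lower numbers for stronger inhibition), compound 1 stands second highest of the three numbers; compound 3 lies nearest to it, with a 3.4-fold higher number from compound 1 to compound 3 (0.53 log units; beyond the scatter), and compound 2 lies furthest, with a 7.0-fold lower number from compound 1 to compound 2 (0.85 log units; beyond the scatter). The gap between compound 2 and compound 3 is the widest, a 24-fold higher number from compound 2 to compound 3 (1.37 log units; beyond the scatter).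

Compound 4, `CC(C)c1c(C(=O)NCc2cccc(Cl)c2)nn(-c2ccc(F)cc2)c1OC[C@@H](O)C[C@@H](O)CC(=O)O`, has not been measured. It differs from compound 1 in one place: (3-chlorobenzyl)amino in place of benzyl(ethyl)amino on a carbonyl carbon. Going by the values given here, of the measured steps, the one from compound 1 to compound 2 bears most directly on this change, since it too replaces benzyl(ethyl)amino with a substituted benzylamino group and gave a 7.0-fold lower number from compound 1 to compound 2 (0.85 log units; beyond the scatter). The step to piperidin-1-yl, a 3.4-fold higher number from compound 1 to compound 3 (0.53 log units; beyond the scatter), moved the other way and is less closely related. Compound 4 is therefore expected to show a modest step toward a lower number, a 4.0-fold lower number from compound 1 to compound 4 (0.60 log units; beyond the scatter). The estimate for compound 4 in this assay is 3.5 nM, with a range from 1.2 nM to 10 nM.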

Compound 4, half-maximal inhibitory concentration: 5.4 nM
Estimate against measurement, compound 4: 1.5-fold (0.19 log units) below; the measured number falls inside the stated range.
By their numbers in this assay, from the lowest: compound 2; then compound 4; then compound 1; then compound 3.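

In this assay the lower number seen with the 2,3-difluorobenzyl amide is not confined to that group, since (3-chlorobenzyl)amino on the carbonyl carbon also lowers the number relative to benzyl(ethyl)amino (a 2.6-fold lower number from compound 1 to compound 4 (0.41 log units; beyond the scatter)) and lies well under piperidin-1-yl (an 8.7-fold lower number from compound 3 to compound 4 (0.94 log units; beyond the scatter)). The substitution on the aromatic ring also counts on its own: with the amide hydrogen kept in both compounds, 3-chlorophenyl in place of 2,3-difluorophenyl gives a step beyond the scatter (a 2.7-fold higher number from compound 2 to compound 4 (0.43 log units; beyond the scatter)). Both benzylamino compounds thus stand below compound 1, but to different degrees.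

How much of the step from compound 1 belongs to the loss of the ethyl group and how much to the chlorine stays open, as plain unsubstituted benzylamino does not appear among these compounds. Nothing given here explains any of these steps.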